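Hexylsulfanyl to pentyloxy in a series at the assay limit

This account rests on a few compounds, and the source may have more. Where it says the series, first, only, none or still open, it means among the compounds named here.

Compound 1 `CCCCCCCCSc1nc(N)nc2c1ncn2/C=C1/CC1(CO)CO` and compound 2 `CCCCCCSc1nc(N)nc2c1ncn2/C=C1/CC1(CO)CO` share a core and differ only in the length of the sulfur-linked chain. In an ADME assay on Akata cells (Homo sapiens) for cytotoxicity, with a stated time of 7 days (a higher number here means that more compound is tolerated, a lower number that less compound is tolerated), compound 1 gives > 20000 nM, which is a limit of the assay and not a number. Compound 2 gives > 20000 nM, also a limit and not a number. Within the data shown here, compound 2 therefore has no exact position, and the same holds for the only other measured compound. Among the measured compounds shown here, the series so far offers only (the limit of > 20000 nM in this assay, at which 2 of the 2 values shown sit).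

Compound 3 `CCCCCOc1nc(N)nc2c1ncn2/C=C1/CC1(CO)CO` carries pentyloxy in place of hexylsulfanyl on an aromatic carbon. For the measured compounds named here, the only measured step bearing on this change is a step that the two limits leave unreadable from compound 1 to compound 2. Going by the values given here, it has no readable size, and it alters the chain without replacing the sulfur, so no measured step covers this exchange. No step beyond the scatter is expected in this assay, and no direction can be assigned. The expected step is a number no higher from compound 2 to compound 3 (the limit leaves the size open). For compound 3 the estimate is 20000 nM, with an expected range from 8000 nM to 40000 nM.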

Compound 3, half-maximal cytotoxic concentration: > 20000 nM
Compound 3: a limit, no number (the forecaster's own chance of this, stated with the estimate: 80%); the middle value lies on the limit itself.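

No step linking compound 3 with compound 1 or compound 2 can be read in this assay, and the series still offers only this: the limit of > 20000 nM in this assay, at which 3 of the 3 values shown sit.

The compounds shown leave open where the true cytotoxic concentrations lie, and whether pentyloxy in place of hexylsulfanyl, or a change in chain length, alters cytotoxicity at all.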